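Pentyl in Place of Methoxy on a Weak Lactone Series

A few compounds are considered here, and "the series" means these few. Any claim that something is new, unique, unknown or untested is made for them only; others in the source may bear on it.

Compound 1 `CC(C)(C)c1cn(C[C@H](O)[C@H]2OC(=O)C(OCc3ccccc3)=C2OCc2ccccc2)nn1` and compound 2 `COc1ccc(-c2cn(C/C=C3\OC(=O)C(OCc4ccccc4)=C3OCc3ccccc3)nn2)cc1` share a common core and differ in the group that sits on their triazole. In a functional assay on CFPAC-1 cells (Homo sapiens) for antiproliferative activity, read by MTT assay, with a stated time of 72 h (a higher number here means a weaker inhibitor, a lower number a stronger inhibitor), compound 1 gives 54900 nM. Compound 2 does not give a number in this assay but only a limit, > 100000 nM. From the compounds shown here alone, compound 2 thus stands at the limit of > 100000 nM in this assay, at which 1 of the 2 values shown sits, and how far beyond it the true value lies is unknown.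

Compound 3 `CCCCCc1ccc(-c2cn(C/C=C3\OC(=O)C(OCc4ccccc4)=C3OCc3ccccc3)nn2)cc1` differs from compound 2 in one place: pentyl in place of methoxy on an aromatic carbon. For the measured compounds named here, no step between two measured compounds is available, so nothing here shows what size of change this exchange brings. The step from compound 2 to compound 3 is expected to be an at least 1.2-fold lower number from compound 2 to compound 3 (0.09 log units; that floor lies within the scatter), small and hardly beyond the scatter, if present at all. Compound 3 is expected to give about 80000 nM in this assay, between 30000 nM and 200000 nM, with a fair chance that only a limit is reported again.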

Compound 3, half-maximal inhibitory concentration: > 100000 nM
Compound 3: a limit, no number (the forecaster's own chance of this, stated with the estimate: 50%); at least 1.2-fold (0.09 log units) between middle value and limit.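

In this assay compound 3 gives only a limit, > 100000 nM. For the compounds shown here, compound 2 likewise gives only a limit, so no step from compound 2 to compound 3 can be read. Whether pentyl in place of methoxy changes the activity at all, and by how much, stays open: the limit of > 100000 nM in this assay, at which 2 of the 3 values shown sit.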